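A few compounds are considered here, and "the series" means these few. Any claim that something is new, unique, unknown or untested is made for them only; others in the source may bear on it.

Among the measured compounds shown here, compound 1, `C#CCn1c2ccc([N+](=O)[O-])cc2c(=O)n1Cc1ccccc1`, is the only member of this small set with a numerical result in an ADME assay on L929 cells (Mus musculus) for cytotoxicity, read by resazurin assay, with a stated time of 48 h; on this read-out lower numbers stand for higher toxicity in this test and higher numbers for lower toxicity in this test: compound 1 gives 195000 nM. Compound 2, `COC(=O)CCn1c2ccc([N+](=O)[O-])cc2c(=O)n1Cc1ccccc1`, carries (methoxycarbonyl)methyl in place of ethynyl on a saturated chain carbon bound to an aromatic nitrogen. In this assay compound 2 returns only a limit, > 256000 nM. For the measured compounds named here, the single measured step, an at least 1.3-fold higher number from compound 1 to compound 2 (0.11 log units; that floor lies within the scatter), is therefore the only guide available, and it stays inside the scatter.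

Compound 3, `CNC(=O)CCCn1c2ccc([N+](=O)[O-])cc2c(=O)n1Cc1ccccc1`, has not yet been tested. It differs from compound 1 by 2-(methylcarbamoyl)ethyl in place of ethynyl on a saturated chain carbon bound to an aromatic nitrogen. Both replacements remove the ethynyl, so compound 3 is expected to behave much as compound 2 did in this assay: a small shift, if any, toward a higher number, and a considerable chance that compound 3 also reaches only a limit, because the limit of > 256000 nM in this assay, at which 1 of the 2 values shown sits, already holds one of the two values. The step from compound 1 that is expected reads a 1.3-fold higher number from compound 1 to compound 3 (0.11 log units; within the scatter). Compound 3 is thus estimated at 250000 nM, expected to lie between 130000 nM and 500000 nM.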

Compound 3, concentration lethal to 50% of the cells: > 256000 nM
Compound 3 ended at the assay's limit; the forecaster's own chance of this, stated with the estimate: 55%; middle value at least 1.0-fold (0.01 log units) away from the limit.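

In this assay, the replacement of ethynyl by 2-(methylcarbamoyl)ethyl on a saturated chain carbon bound to an aromatic nitrogen gives an at least 1.3-fold higher number from compound 1 to compound 3 (0.11 log units; that floor lies within the scatter), so a second, different replacement at this place has the same floor as the ester step and no readable change beyond the scatter. Compound 2 had shown this only for an ester, whereas compound 3 shows that a chain ending in an amide, with its 1 hydrogen-bond donor, also leaves the read-out at a limit rather than at a number that can be compared with compound 1. The step from compound 2 to compound 3 cannot be read, so nothing can be said about ester against amide, and the series now sits mostly at one end of the read-out: the limit of > 256000 nM in this assay, at which 2 of the 3 values shown sit.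

On these data alone, it remains open whether an amine or a carboxylic acid at the end of this chain, or a longer chain, would also stay at the limit or would return a number in this assay. As far as these compounds go, it is equally open how far compound 2 and compound 3 really lie from compound 1, and whether removing ethynyl changes the result at all.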